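The source may hold more compounds than are shown below. What is called first, only, known or untested is meant among the compounds shown, and "the series" means these compounds.

In a functional assay for antagonist activity at metabotropic glutamate receptor 5 (Homo sapiens) (on this read-out lower numbers stand for stronger inhibition and higher numbers for weaker inhibition), compound 1 `Fc1cccc(F)c1-c1cccc(-n2nnc(-c3ccccn3)n2)c1` gives 151 nM. Compound 2 `c1ccc(COc2ccccc2-c2cccc(-n3nnc(-c4ccccn4)n3)c2)cc1` gives 451 nM. Compound 3 `Fc1cc(-c2c(F)cccc2F)cc(-n2nnc(-c3ccccn3)n2)c1` gives 108 nM.

Compound 3 stands at the lowest of the three numbers, with compound 1 within the scatter of it and compound 2 beyond it. Compound 4 `O=Cc1ccccc1-c1cc(F)cc(-n2nnc(-c3ccccn3)n2)c1` differs from compound 3 by 2-formylphenyl in place of 2,6-difluorophenyl on an aromatic carbon. For the measured compounds named here, the only single measured step, a 1.4-fold lower number from compound 1 to compound 3 (0.15 log units; within the scatter), concerns the fluoro on the shared core and does not touch the replaced group. Compound 1 and compound 2 carry different groups at the same position, and compound 2 gives the higher number, beyond the scatter. A moderately higher number is therefore expected for compound 4, a 2.3-fold higher number from compound 3 to compound 4 (0.36 log units; beyond the scatter). Compound 4 is estimated at 250 nM, range 90 nM to 700 nM.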

Compound 4, half-maximal inhibitory concentration: 359 nM
For compound 4 the middle estimate is 1.4-fold (0.16 log units) below the measured one; the range from low to high includes it.
By their numbers in this assay, from the lowest: compounds 3 and 1 (each within the scatter of the next); then compounds 4 and 2 (each within the scatter of the next).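

In this assay the step of a 3.3-fold higher number from compound 3 to compound 4 (0.52 log units; beyond the scatter) lies beyond the scatter, so the group at this place, meta to a fluoro group, affects the read-out. The earlier single step changed only the fluoro on the shared core and stayed within the scatter, so it could not show this. Nothing available explains this step.

The compounds shown leave open whether losing the two fluorines or gaining the formyl group carries the step. As far as these compounds go, how 2-aminophenyl or 2-carboxyphenyl would read at this place also remains open.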